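The compounds below may be only part of what the source reports. "The series", "measured", "known", "first", "only" and "open" are said of these compounds alone.

Measured compounds:
compound 1, `CCc1ccc(CN[C@@H]2C[C@H]3C[C@@H]([C@H]2C)C3(C)C)s1` — 1560 nM
compound 2, `C[C@H]1[C@H](NCc2cncs2)C[C@H]2C[C@@H]1C2(C)C` — > 100000 nM
compound 3, `C[C@H]1[C@H](NCc2cc(-c3ccccc3)cs2)C[C@H]2C[C@@H]1C2(C)C` — 5000 nM

Three amines on a shared bicyclic core have been examined in an ADME assay on MDCK cells (Canis lupus familiaris) for cytotoxicity, read by microscopy, with a stated time of 48 h; a lower number here means that less compound is tolerated, a higher number that more compound is tolerated. Compound 1 gives 1560 nM in this assay. Compound 3 gives 5000 nM. For compound 2 the result is only a limit of the assay and not a number: compound 2 gives > 100000 nM. Among the measured compounds shown here, compound 2 is thus the one compound of the three that sits at the limit of > 100000 nM in this assay, at which 1 of the 3 values shown sits, and nothing in the data places it at a number.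

Compound 4, `Cc1n[nH]cc1CN[C@@H]1C[C@H]2C[C@@H]([C@H]1C)C2(C)C`, has not yet been measured. It differs from compound 2 in one place: 3-methyl-1H-pyrazol-4-yl in place of 1,3-thiazol-5-yl on a saturated chain carbon bound to an amine nitrogen. For the measured compounds named here, no step between two measured compounds is available for this kind of change, so the direction and size of the step can only be expected, not derived. The expectation is for no step beyond the usual scatter in this assay, with the result again most likely reported as a limit.

Because compound 2 already stands at the limit of > 100000 nM in this assay, at which 1 of the 3 values shown sits, compound 4 is expected to give 80000 nM in this assay, with a range from 25000 nM to 100000 nM. The expected step is an at least 1.2-fold lower number from compound 2 to compound 4 (0.09 log units; that floor lies within the scatter).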

Compound 4, minimum cytotoxic concentration: > 100000 nM
Compound 4 was reported as a limit (the forecaster's own chance of this, stated with the estimate: 60%); at least 1.2-fold (0.09 log units) between middle value and limit.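

Compound 2 and compound 4 both stand at a limit in this assay and not at a number, so no step can be read from one to the other: the limit of > 100000 nM in this assay, at which 2 of the 4 values shown sit. On these data alone, how 3-methyl-1H-pyrazol-4-yl compares with 1,3-thiazol-5-yl in this assay therefore remains open.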